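Aryl ketone variation and cytotoxicity on fibroblast cells

The source may report more compounds than this note shows. Statements on the series, on what has been measured and on what is new or still open speak of the compounds shown alone.

In a functional assay on WI-38 VA13 cells (Homo sapiens) for cytotoxicity (on this read-out lower numbers stand for an effect already at smaller amounts and higher numbers for an effect only at larger amounts of compound), the measured compounds stand as follows:
compound 1 `COc1ccc(C(=O)c2sc3nc(-c4cccs4)ccc3c2N)cc1`: 0.77 ug/mL
compound 2 `COc1ccc(OC)c(C(=O)c2sc3nc(-c4cccs4)ccc3c2N)c1`: 0.079 ug/mL
compound 3 `COc1cccc(C(=O)c2sc3nc(-c4cccs4)ccc3c2N)c1`: 0.03 ug/mL

Compound 3 gives the lowest number of the three; compound 2 sits nearest to it and compound 1 furthest away. Both measured steps end at compound 3: a 26-fold lower number from compound 1 to compound 3 (1.41 log units; beyond the scatter) and a 2.6-fold lower number from compound 2 to compound 3 (0.42 log units; beyond the scatter). Compound 4 `Nc1c(C(=O)c2ccc(F)cc2F)sc2nc(-c3cccs3)ccc12` differs from compound 3 only in the aryl group on the carbonyl: 2,4-difluorophenyl in place of 3-methoxyphenyl on a carbonyl carbon. Among the compounds with values here, no measured step tests fluorine in place of methoxy, nor a ring carrying two substituents of this kind; the steps that bear on it show only that altering the aryl group on the carbonyl moved this assay by modest to large amounts. The expectation is therefore a step upward in this assay of uncertain size, a 5.0-fold higher number from compound 3 to compound 4 (0.70 log units; beyond the scatter). Compound 4 is estimated at 0.15 ug/mL, with a range from 0.03 ug/mL to 0.8 ug/mL.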

Compound 4, half-maximal effective concentration: 2.3 ug/mL
Compound 4: the middle estimate sits 15-fold (1.19 log units) below what was measured; measured number outside the range, above it.
By their numbers in this assay, from the lowest: compound 3; then compound 2; then compound 1; then compound 4.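

In this assay, replacing a methoxy-bearing aryl group on the carbonyl carbon with 2,4-difluorophenyl raises the number, with a 77-fold higher number from compound 3 to compound 4 (1.88 log units; beyond the scatter) and a 3.0-fold higher number from compound 1 to compound 4 (0.48 log units; beyond the scatter). Compound 4 therefore stands highest of the four, so this position can move the number upward past all three methoxy compounds, not only among them. Nothing measured here accounts for the rise.

On these data alone, it remains open whether the change follows from the fluorines themselves or from their arrangement on the ring. Also open, as far as these compounds go, is how a single fluorine, an amine or a carboxylic acid on this aryl group would stand.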